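Moving a Hydroxyl Group on a Shared Core

The source may report more compounds than this note shows. Statements on the series, on what has been measured and on what is new or still open speak of the compounds shown alone.

In an assay on isolated protein for inhibition of DNA topoisomerase 1 (Homo sapiens), with a stated time of 30 min, tested at 100 uM (on this read-out lower numbers stand for a weaker effect and higher numbers for a stronger effect at the one concentration tested), compound 1 `Oc1cccc(-c2cc(-c3ccco3)nc(-c3ccccc3Cl)c2)c1` gives 0%. Compound 2 `Oc1cccc(-c2cc(-c3ccsc3)nc(-c3cccc(Cl)c3)c2)c1` gives 26.2% in this assay, and compound 3 `Oc1ccc(-c2cc(-c3cccc(Cl)c3)nc(-c3ccco3)c2)cc1` gives 25.5%. Among these three numbers compound 3 stands second highest; its nearest neighbour is compound 2, whose number lies within the scatter of it, while compound 1 sits furthest away, beyond the scatter.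

Compound 4 `Oc1cccc(-c2cc(-c3cccc(Cl)c3)nc(-c3ccco3)c2)c1` has not yet been measured. It has the same atoms as compound 3, joined differently: 3-hydroxyphenyl in place of 4-hydroxyphenyl on an aromatic carbon. The hydroxyphenyl group sits on an aromatic carbon of the six-membered aromatic ring with one nitrogen, opposite the ring nitrogen, and only the place of the hydroxyl on that hanging ring differs.

For the measured compounds named here, no pair of measured compounds differs by this change alone, so the size of the step cannot be read off directly. Going by the values given here, compounds 1 and 2 both carry a 3-hydroxyphenyl group, yet they differ from compound 3 in other places as well, so their numbers show only that this group is compatible with both a negligible and a moderate read-out. A step within the scatter, in no firm direction, is expected: a number 1.5 percentage points lower from compound 3 to compound 4 (within the scatter). Compound 4 is therefore estimated at 24%, with a likely range from 8% to 40%.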

Compound 4, a percentage reported as inhibition, at one concentration (the size of the read-out at that concentration, not a potency): 5.5%
The estimate for compound 4 lay 18.5 percentage points above the measured number; the whole stated range lies above it.
By their numbers in this assay, from the lowest: compounds 1 and 4 (each within the scatter of the next); then compounds 3 and 2 (each within the scatter of the next).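

For the compounds shown here, compound 3 and compound 4 have the same atoms and differ only in where the hydroxyl sits on the hanging ring, so this pair isolates that change for the first time: in this assay, 3-hydroxyphenyl in place of 4-hydroxyphenyl gives a number 20 percentage points lower from compound 3 to compound 4 (beyond the scatter), with the 3-chlorophenyl and furan-2-yl groups held fixed. With the 3-hydroxyphenyl group kept in place, the other groups can also be compared one at a time: furan-2-yl in place of thiophen-3-yl gives a number 20.7 percentage points lower from compound 2 to compound 4 (beyond the scatter), whereas 3-chlorophenyl in place of 2-chlorophenyl gives a number 5.5 percentage points higher from compound 1 to compound 4 (within the scatter), so only the first of these two swaps gives a step that can be told apart from repeat-to-repeat variation. Nothing among the data shown explains why the place of the hydroxyl or the choice of the five-membered ring matters.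

The compounds shown leave open how a 2-hydroxyphenyl group would read, or a methoxy group or an amine where the hydroxyl now stands. They also leave open whether moving the hydroxyl has a similar effect when thiophen-3-yl replaces furan-2-yl on the shared core.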